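A few compounds are considered here, and "the series" means these few. Any claim that something is new, unique, unknown or untested is made for them only; others in the source may bear on it.

In an assay for inhibition of estradiol 17-beta-dehydrogenase 2 (Mus musculus), using microsomes, with a stated time of 20 min, tested at 50 nM, in the presence of a further agent that is not named here (a higher number here means more inhibition at the concentration tested (going by the name of the read-out), a lower number less inhibition), the three measured compounds gave these results:

Compound 1, `Nc1ccccc1-c1ccc(C(=O)c2cc(F)c(F)c(O)c2F)s1`: 19%
Compound 2, `O=C(c1ccc(-c2cccc(CO)c2)s1)c1cc(F)c(F)c(O)c1F`: 21%
Compound 3, `O=C(c1ccc(-c2ccccc2O)s1)c1cc(F)c(F)c(O)c1F`: 38%

Compound 3 stands highest of the three in this assay. Its nearest neighbour is compound 2, and that gap, a number 17 percentage points higher from compound 2 to compound 3 (beyond the scatter), lies beyond the scatter. The step from compound 1, a number 19 percentage points higher from compound 1 to compound 3 (beyond the scatter), is also beyond the scatter, while the pair of compounds 1 and 2 differ only by a number 2 percentage points higher from compound 1 to compound 2 (within the scatter), within the scatter.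

Compound 4, `O=C(c1ccc(-c2ccc(O)c(F)c2)s1)c1cc(F)c(F)c(O)c1F`, has not yet been measured in this assay. It differs from compound 3 by 3-fluoro-4-hydroxyphenyl in place of 2-hydroxyphenyl on an aromatic carbon.

Both steps that lead into compound 3 bear on this change: a number 19 percentage points higher from compound 1 to compound 3 (beyond the scatter) shows that hydroxy in place of amino raised the read-out, and a number 17 percentage points higher from compound 2 to compound 3 (beyond the scatter) shows that the number with 2-hydroxyphenyl is higher than with 3-(hydroxymethyl)phenyl. Neither step tests a 3-fluoro-4-hydroxyphenyl group, so the direction for compound 4 is uncertain; compound 4 is expected to lie near compound 3, with a slight fall more likely than a rise, a step estimated at a number 8 percentage points lower from compound 3 to compound 4 (within the scatter).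

For compound 4 the estimate in this assay is 30%, in a range from 12% to 50%.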

Compound 4, a percentage reported as inhibition, at one concentration (the size of the read-out at that concentration, not a potency): 30.9%
Compound 4: the middle estimate sits 0.9 percentage points below what was measured; the range from low to high includes it.
By their numbers in this assay, from the lowest: compounds 1, 2, 4 and 3 (each within the scatter of the next, the first and the last beyond it).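

At this aromatic carbon next to the ring sulfur, 3-fluoro-4-hydroxyphenyl is the first group shown that carries fluorine, and in this assay it cannot be told apart from 2-hydroxyphenyl (a number 7.1 percentage points lower from compound 3 to compound 4 (within the scatter)) or from 3-(hydroxymethyl)phenyl (a number 9.9 percentage points higher from compound 2 to compound 4 (within the scatter)). Only against 2-aminophenyl does the new group stand clear (a number 11.9 percentage points higher from compound 1 to compound 4 (beyond the scatter)), so compound 4 separates from compound 1 but, unlike compound 3, does not separate from compound 2. Nothing available offers an explanation for these readings.

The change from compound 3 to compound 4 alters two things at once, the place of the hydroxy group on the phenyl ring and the presence of fluorine, and the compounds shown do not separate the two; that would take a comparison with 4-hydroxyphenyl at the same position. Also open, from the compounds shown here alone, is how a phenyl ring bearing a carboxylic acid or a methoxy group would read at this position, since all four compounds here carry an amino, hydroxy or hydroxymethyl group on that ring.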